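The source may hold more compounds than are shown below. What is called first, only, known or untested is meant among the compounds shown, and "the series" means these compounds.

Of the compounds shown here, three sharing one core have been tested, and all three give the same result. Compound 1 `CC(C(=O)N1CCN(c2ccc(Cl)cc2)CC1)N1C(=O)CCC1=O` gives 0% in a functional assay on the whole organism (strain Swiss) with Mus musculus as the target, in the maximal electroshock model, with a stated time of 1 h, at a dose of 100 mg/kg by the intraperitoneal route; a lower number here means a weaker effect, a higher number a stronger effect of the compound at the dose given. Compound 2 `CCC(C(=O)N1CCN(c2cccc(F)c2)CC1)N1C(=O)CCC1=O` gives 0% in this assay, and compound 3 `CC(C(=O)N1CCN(c2cccc(F)c2)CC1)N1C(=O)CCC1=O` gives 0%. Compound 2 therefore stands level with compound 1 and compound 3; the step of no change at the digits printed from compound 1 to compound 3 (within the scatter) and the step of no change at the digits printed from compound 2 to compound 3 (within the scatter) were both flat, one a swap of the group on the amine nitrogen in a ring, the other a change on the saturated chain carbon.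

Compound 4 `CCC(C(=O)N1CCN(c2cccc(C)c2)CC1)N1C(=O)CCC1=O` has not yet been measured. It differs from compound 2 by methyl in place of fluoro on an aromatic carbon, placed on an aromatic carbon of a six-membered aromatic ring of carbon only.

Within the data shown here, the step that bears most on this change is the one from compound 1 to compound 3, where a different group on the same aromatic ring left the read-out unchanged; the step from compound 2 to compound 3 shows the same flatness elsewhere in the molecule. Among the measured compounds shown here, nothing among the measured compounds suggests that the ring substituent moves the read-out, so for compound 4 a step of no change at the digits printed from compound 2 to compound 4 (within the scatter) is expected, that is no change beyond the scatter. Compound 4 is therefore estimated at 0%, within a range from 0% to 15%.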

Compound 4, a percentage reported as activity, at one dose (the size of the read-out at that dose, not a potency): 0%
The estimate for compound 4 equals the measured number at the digits printed; measured number inside the range.
By their numbers in this assay, from the lowest: compounds 1, 2, 3 and 4 (each within the scatter of the next).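

Unlike the earlier ring change from 4-chlorophenyl to 3-fluorophenyl, which altered both the group and its place, the change from 3-fluorophenyl to 3-methylphenyl swaps fluoro for methyl at a single place, meta to a large group, and in this assay the step reads no change at the digits printed from compound 2 to compound 4 (within the scatter). With compound 4 at 0%, both ends of this step sit at zero, so it gives no way of ranking fluoro and methyl at this place: neither compound shows an effect against which a difference could appear. No supporting measurement bears on why this swap leaves the read-out flat.

The compounds shown leave open whether any other group at this place, such as methoxy, trifluoromethyl, a nitrile or an amine, would lift the read-out above zero. They also leave open whether fluoro and methyl would still read alike on a core that does show protection in this model, for instance one with a longer chain on the saturated carbon.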